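The source may report more compounds than this note shows. Statements on the series, on what has been measured and on what is new or still open speak of the compounds shown alone.

Measured so far:

Compound 1, `O=C(CN(c1nc(Cl)nc2[nH]cnc12)C1CC1)N[C@@H](CC(=O)OCc1ccccc1)C(=O)OCc1ccccc1`: 6.68%
Compound 2, `CSCC[C@H](NC(=O)CN(c1nc(Cl)nc2[nH]cnc12)C1CC1)C(=O)OCc1ccccc1`: 17.6%

In a functional assay on the whole organism (Tail, strain ICR) with Mus musculus as the target, in the tail flick test, with a stated time of 150 min, at a dose of 25 umol/kg by the oral route (on this read-out higher numbers stand for a stronger effect at the one dose given and lower numbers for a weaker effect), compound 1 gives 6.68% and compound 2 gives 17.6%, so compound 2 stands higher of the two, the gap being a number 10.9 percentage points higher from compound 1 to compound 2 (beyond the scatter).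

Compound 3, `CC(C)C[C@H](NC(=O)CN(c1nc(Cl)nc2[nH]cnc12)C1CC1)C(=O)OCc1ccccc1`, differs from compound 2 by isopropyl in place of (methylsulfanyl)methyl on a saturated chain carbon, two bonds along the chain from an amide-type nitrogen and a carbonyl carbon. Going by the values given here, the only measured step at this place is a number 10.9 percentage points higher from compound 1 to compound 2 (beyond the scatter), a modest rise, but it swaps a different group and says little about exchanging (methylsulfanyl)methyl for isopropyl. The expected step of a number 0.6 percentage points lower from compound 2 to compound 3 (within the scatter) is therefore small, with no clear direction beyond the scatter. Compound 3 is estimated at 17%, between 5% and 32%.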

Compound 3, a percentage reported as activity, at one dose (the size of the read-out at that dose, not a potency): 5.26%
Compound 3: middle estimate off by 11.7 percentage points, on the high side; low and high end bracket the measured number.
By their numbers in this assay, from the lowest: compounds 3 and 1 (each within the scatter of the next); then compound 2.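

In this assay, swapping (methylsulfanyl)methyl for isopropyl, a group with the same heavy-atom count but carbon in place of sulfur, gives a number 12.3 percentage points lower from compound 2 to compound 3 (beyond the scatter) and shows that this small exchange at the saturated chain carbon can change the read-out. Isopropyl and benzyloxycarbonyl do not separate, with a number 1.4 percentage points lower from compound 1 to compound 3 (within the scatter) within the scatter, so among these three only compound 2 stands apart. No supporting data explain this difference.

Open, as far as these compounds go, is whether 2-methoxyethyl, an amine or a carboxylic acid at this place would hold the level of compound 2.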